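Estimating Compound 4: Piperidine Amide to Methoxyphenyl Amide

This account rests on a few compounds, and the source may have more. Where it says the series, first, only, none or still open, it means among the compounds named here.

Among the compounds with numbers in a functional assay on SH-SY5Y cells (Homo sapiens), read by MTT assay, with a stated time of 24 h (on this read-out lower numbers stand for an effect already at smaller amounts and higher numbers for an effect only at larger amounts of compound), compound 3 `COc1ccc(Cl)cc1N(CC(=O)N1CCCCC1)S(=O)(=O)c1ccccc1` gives 14500 nM, the highest of the two; the nearest is compound 1 `CCn1ccc2cc(NC(=O)CN(c3cc(Cl)ccc3OC)S(=O)(=O)c3ccccc3)ccc21` at 2220 nM. Compound 2 `CCN(CC)C(=O)CN(c1cc(Cl)ccc1OC)S(=O)(=O)c1ccccc1` gives only a limit, > 20000 nM, in this assay (the limit of > 20000 nM in this assay, at which 1 of the 3 values shown sits). Going by the values given here, the one measured step is an at least 1.3-fold lower number from compound 2 to compound 3 (0.13 log units; that floor lies within the scatter), a size that lies within the scatter. Compound 4 `COc1cccc(NC(=O)CN(c2cc(Cl)ccc2OC)S(=O)(=O)c2ccccc2)c1` differs from compound 3 by (3-methoxyphenyl)amino in place of piperidin-1-yl on a carbonyl carbon. Among the compounds with values here, no measured step swaps a ring amine for an amino group attached to an aromatic ring, but compound 1, whose carbonyl carbon also bears such a group, shows the lower of the two numbers. Compound 4 is therefore expected to reach 4000 nM, between 1500 nM and 12000 nM. The expected step is a 3.6-fold lower number from compound 3 to compound 4 (0.56 log units; beyond the scatter).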

Compound 4, half-maximal effective concentration: 17600 nM
For compound 4 the middle estimate is 4.4-fold (0.64 log units) below the measured one; measured number outside the range, above it.
By their numbers in this assay, from the lowest: compound 1; then compounds 3 and 4 (each within the scatter of the next). At a limit, above all of these: compound 2.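

In this assay, the change on this carbonyl carbon gives a 1.2-fold higher number from compound 3 to compound 4 (0.08 log units; within the scatter), so an aromatic ring on the amide nitrogen does not by itself bring the number down to that of compound 1. The group on that nitrogen does matter, as 3-methoxyphenyl in place of 1-ethyl-1H-indol-5-yl gives a 7.9-fold higher number from compound 1 to compound 4 (0.90 log units; beyond the scatter). Compound 2 gives only a limit of the assay, so an at least 1.1-fold lower number from compound 2 to compound 4 (0.05 log units; that floor lies within the scatter) is a floor and no more: the limit of > 20000 nM in this assay, at which 1 of the 4 values shown sits.

Still open, on these data alone, is whether a pyridin-3-yl or a 1-ethyl-1H-indol-6-yl group on that nitrogen would stay near compound 4 or move towards compound 1. The compounds shown also do not tell why 1-ethyl-1H-indol-5-yl goes with the lower number.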